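A few compounds are considered here, and "the series" means these few. Any claim that something is new, unique, unknown or untested is made for them only; others in the source may bear on it.

Measured so far:
compound 1 `C(=C/c1ccccc1)\C=N\c1sc2c(c1-c1nc3ccccc3s1)CCCC2`: 207 ug/mL
compound 2 `Oc1ccccc1/C=N/c1sc2c(c1-c1nc3ccccc3s1)CCCC2`: 42.4 ug/mL
compound 3 `Oc1ccccc1/C=N/c1sc2c(c1-c1nc3cc(Cl)ccc3s1)CCC2`: 269 ug/mL

All three were read in an ADME assay on cells (Rhabdomyosarcoma cell, Homo sapiens) for cytotoxicity, read by MTT assay, with a stated time of 72 h; on this read-out lower numbers stand for higher toxicity in this test and higher numbers for lower toxicity in this test. Compound 4 `Clc1ccc2sc(-c3c(/N=C/C=C/c4ccccc4)sc4c3CCC4)nc2c1` is not yet measured in this assay.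

Compound 2 and compound 3 share the same aryl group on the imine carbon; how their two cores differ is not broken down here. Compound 3 gives the highest number of the three, and its gap to compound 2 lies beyond the scatter, while its gap to compound 1 lies within it.

The change made between compound 2 and compound 1 is 2-phenylethenyl in place of 2-hydroxyphenyl on a carbon with a double bond to nitrogen, with a step of a 4.9-fold higher number from compound 2 to compound 1 (0.69 log units; beyond the scatter). The change from compound 3 to compound 4 is 2-phenylethenyl in place of 2-hydroxyphenyl on a carbon with a double bond to nitrogen, the same change at the same place.

For compound 4 a higher number in this assay than compound 3 is expected, with a step around a 2.2-fold higher number from compound 3 to compound 4 (0.35 log units; beyond the scatter), because the same change gave a 4.9-fold higher number from compound 2 to compound 1 (0.69 log units; beyond the scatter). Compound 3 already stands at 269 ug/mL. For compound 4 the estimate is 600 ug/mL (range 250 ug/mL to 1300 ug/mL).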

Compound 4, half-maximal cytotoxic concentration: 122 ug/mL
The estimate for compound 4 lay 4.9-fold (0.69 log units) above the measured number; the measured number lies below the stated range.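

In this assay, 2-phenylethenyl in place of 2-hydroxyphenyl on a carbon with a double bond to nitrogen gives a 2.2-fold lower number from compound 3 to compound 4 (0.34 log units; beyond the scatter) on this second core. The change therefore does not carry over between these two cores, in size or in direction: the same change on two cores in this assay, a 4.9-fold higher number (0.69 log units; beyond the scatter) from compound 2 to compound 1 and a 2.2-fold lower number (0.34 log units; beyond the scatter) from compound 3 to compound 4, 11-fold (1.03 log units) apart, beyond the scatter of two such steps. This shows that the step cannot be transferred between these cores in this assay, but two pairs do not show which difference between the cores goes with the reversal, nor which direction is usual in the series.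

Still open, going by these compounds, is whether further cores follow the step of compound 1 or that of compound 4. Also open, on these data alone, is how other groups on this carbon, such as an amine or a carboxylic acid, would behave on each core.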